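From a Small Fluoro Group to a Long Acid Chain

The source may hold more compounds than are shown below. What is called first, only, known or untested is meant among the compounds shown, and "the series" means these compounds.

Of the compounds shown here, three that share one core have been tested in an ADME assay on BHK cells (Mesocricetus auratus) for cytotoxicity, read by MTT assay, with a stated time of 96 h; on this read-out lower numbers stand for higher toxicity in this test and higher numbers for lower toxicity in this test. Compound 1 `Oc1ccc(-c2nc3cc(C(F)(F)F)ccc3[nH]2)cc1` reads > 100000 nM, which is a limit of the assay and not a number. Compound 2 `O=[N+]([O-])c1ccc(-c2nc3cc(C(F)(F)F)ccc3[nH]2)cc1` gives 18000 nM. Compound 3 `Fc1ccc(-c2nc3cc(C(F)(F)F)ccc3[nH]2)cc1` gives 25000 nM. These last two numbers lie close together, with a 1.4-fold higher number from compound 2 to compound 3 (0.14 log units; within the scatter).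

Compound 4 `O=C(O)CCC(=O)Nc1ccc(-c2nc3cc(C(F)(F)F)ccc3[nH]2)cc1` carries ((2-carboxyethyl)carbonyl)amino in place of fluoro on an aromatic carbon. The measured steps change the group on this same carbon, so they are the best guide available. Replacing hydroxy gave an at least 5.5-fold lower number from compound 1 to compound 2 (0.74 log units; beyond the scatter) and an at least 4.0-fold lower number from compound 1 to compound 3 (0.60 log units; beyond the scatter). None of these groups closely resembles the new chain, so these steps indicate a likely size better than a direction. Because an at least 4.0-fold lower number from compound 1 to compound 3 (0.60 log units; beyond the scatter) shows that a change on this carbon can move the number beyond the scatter, a modest step is expected for the much larger group. A rise in this assay is the more likely direction, though compound 4 may also reach the limit. The expected step is a 2.4-fold higher number from compound 3 to compound 4 (0.38 log units; beyond the scatter). The estimate for compound 4 is 60000 nM, with an expected range from 20000 nM to 100000 nM.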

Compound 4, half-maximal cytotoxic concentration: > 100000 nM
Compound 4: only a limit was reported; the forecaster's own chance of this, stated with the estimate: 45%; middle value at least 1.6-fold (0.22 log units) away from the limit.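

Placing the ((2-carboxyethyl)carbonyl)amino chain on this carbon in this assay gives an at least 4.0-fold higher number from compound 3 to compound 4 (0.60 log units; beyond the scatter) and also an at least 5.5-fold higher number from compound 2 to compound 4 (0.74 log units; beyond the scatter) as the matching step from the nitro group. Compound 4 reads > 100000 nM and this is a limit of the assay and not a number. The position can therefore carry a much larger group than hydroxy, nitro or fluoro while the read-out stays at the top of the range, so hydroxy in compound 1 and the long chain in compound 4 end at the same limit, unlike the fluoro of compound 3 and the nitro of compound 2, and the step between compound 1 and compound 4 cannot be read: the limit of > 100000 nM in this assay, at which 2 of the 4 values shown sit.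

The compounds shown do not say which part of the chain goes with the higher number, since the amide and the end group change together. A simple amine or a carboxylic acid alone on this carbon would begin to separate those parts, and a shorter or longer chain would show whether its length matters at all.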